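This account rests on a few compounds, and the source may have more. Where it says the series, first, only, none or still open, it means among the compounds named here.

Compound 1 `CCCOC(=O)CCC(=O)N1CCN(CCCOc2cc3c(Nc4ccc(F)c(Cl)c4)ncnc3cc2OC)CC1` and compound 2 `CCCCCCOC(=O)CCC(=O)N1CCN(CCCOc2cc3c(Nc4ccc(F)c(Cl)c4)ncnc3cc2OC)CC1` share one core and differ only in the ester chain. In a functional assay on A549 cells (Homo sapiens) for cytotoxicity, read by MTT assay, with a stated time of 24 h, tested at 20 uM (on this read-out lower numbers stand for a stronger effect and higher numbers for a weaker effect at the one concentration tested), compound 1 gives 87% and compound 2 gives 85.1%; the step of a number 1.9 percentage points lower from compound 1 to compound 2 (within the scatter) stays within the scatter. Among the two measured numbers, compound 2 stands last, though only within the scatter of compound 1. Compound 3 `CCCCCCCCOC(=O)CCC(=O)N1CCN(CCCOc2cc3c(Nc4ccc(F)c(Cl)c4)ncnc3cc2OC)CC1` differs from compound 2 by ethyl in place of hydrogen on a saturated chain carbon, six bonds along the chain from an oxygen next to a carbonyl group. Going by the values given here, the single step that bears on this, also a longer chain at the same place, a number 1.9 percentage points lower from compound 1 to compound 2 (within the scatter), was within the scatter, so no step beyond the scatter is expected in this assay. Compound 3 is therefore estimated at 84%, between 74% and 94%, an expected step of a number 1.1 percentage points lower from compound 2 to compound 3 (within the scatter).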

Compound 3, a percentage reported as activity, at one concentration (the size of the read-out at that concentration, not a potency): 80%
Compound 3: middle estimate off by 4 percentage points, on the high side; measured number inside the range.
By their numbers in this assay, from the lowest: compounds 3, 2 and 1 (each within the scatter of the next).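

In this assay, ethyl in place of hydrogen six bonds along the chain from an oxygen next to a carbonyl group gives a number 5.1 percentage points lower from compound 2 to compound 3 (within the scatter) and pentyl in place of hydrogen three bonds along that chain gives a number 7 percentage points lower from compound 1 to compound 3 (within the scatter) as the larger change shown. Even this larger extension of the ester chain therefore stays within the scatter, so chain length does not separate these three compounds at the one concentration tested. Nothing measured here speaks to what lies behind these numbers. On these data alone, what a still longer chain would give stays open, as does the result of an amine or a carboxylic acid on this chain.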